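Ester to Acid on Two Different Cores

The compounds below may be only part of what the source reports. "The series", "measured", "known", "first", "only" and "open" are said of these compounds alone.

Measured compounds:
Compound 1, `COC(=O)c1cccc2c(C(=O)c3ccccc3)cc(C(=O)c3ccc(C(F)(F)F)cc3)c-2c1`: 10.4%
Compound 2, `O=C(O)c1cccc2c(C(=O)c3ccccc3)cc(C(=O)c3ccc(C(F)(F)F)cc3)c-2c1`: 18.3%
Compound 3, `COC(=O)c1ccc2ccc(C=O)c-2cc1`: 25%

In an assay on cells for displacement of a labelled ligand from Orexin/Hypocretin receptor type 1 (Homo sapiens), read by scintillation counting, with stated times of 10 min and 90 min, tested at 10 uM (a higher number here means more inhibition at the concentration tested (going by the name of the read-out), a lower number less inhibition), compound 1 gives 10.4%, compound 2 gives 18.3% and compound 3 gives 25%. Compound 2 is obtained from compound 1 by the change (hydrogen in place of methyl on an oxygen next to a carbonyl group), and this step reads a number 7.9 percentage points higher from compound 1 to compound 2 (within the scatter). The difference between the cores of compound 1 and compound 3 is not broken down here. Compound 3 stands above compound 1 by a gap beyond the scatter, while compound 3 and compound 2 lie within the scatter of each other.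

The unmeasured compound 4, `O=Cc1ccc2ccc(C(=O)O)ccc1-2`, differs from compound 3 by hydrogen in place of methyl on an oxygen next to a carbonyl group, the same change as that from compound 1 to compound 2, at the same kind of place. Because a number 7.9 percentage points higher from compound 1 to compound 2 (within the scatter) stayed within the scatter, compound 4 is expected to lie close to compound 3, with a step of about a number 6 percentage points higher from compound 3 to compound 4 (within the scatter). Compound 4 is estimated at 31%, expected between 17% and 45%.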

Compound 4, a percentage reported as inhibition, at one concentration (the size of the read-out at that concentration, not a potency): 37.8%
Compound 4: middle estimate off by 6.8 percentage points, on the low side, within the range that was stated.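

In this assay the change from methoxycarbonyl to carboxy reads a number 12.8 percentage points higher from compound 3 to compound 4 (beyond the scatter) and so points the same way on the core of compound 3 as it did on the core of compound 1. For the compounds shown here, this does not show that the change adds a fixed amount on every core: two cores are too few for that, and the fact that only one of the two steps lies beyond the scatter does not mean that the cores respond differently. What can be said is that the two steps cannot be told apart in size: the same change on two cores in this assay, a number 7.9 percentage points higher (within the scatter) from compound 1 to compound 2 and a number 12.8 percentage points higher (beyond the scatter) from compound 3 to compound 4, 4.9 percentage points apart, within the scatter of two such steps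

The compounds shown leave open how other groups would read in the place of the methoxycarbonyl on either core, for example an amide, a nitrile or a longer ester such as ethoxycarbonyl. They also leave open whether the same change keeps its direction on a third core, or when other groups on the core of compound 3 are altered.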